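Changing One Aromatic End Group in a Cytotoxicity Series

The source may hold more compounds than are shown below. What is called first, only, known or untested is meant among the compounds shown, and "the series" means these compounds.

Measured compounds:
compound 1 `COc1cc(/C=C/C(=O)/C=C/c2cccc3ccccc23)ccc1OCc1cn(CCOc2cc(=O)oc3ccccc23)nn1` gives 6540 nM
compound 2 `COc1cc(/C=C/C(=O)/C=C/c2cccs2)ccc1OCc1cn(CCOc2cc(=O)oc3ccccc23)nn1` gives 9290 nM

Both were tested in a functional assay on HCT-116 cells (Homo sapiens) for cytotoxicity, read by sulforhodamine B assay, with a stated time of 48 h; on this read-out higher numbers stand for weaker inhibition and lower numbers for stronger inhibition. Compound 2 has the highest of the two numbers, but its nearest neighbour, compound 1, lies only slightly lower, within the scatter, so the two cannot be ordered.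

The next compound, compound 3 `COc1cccc(/C=C/C(=O)/C=C/c2ccc(OCc3cn(CCOc4cc(=O)oc5ccccc45)nn3)c(OC)c2)c1`, is not yet measured. It differs from compound 2 in one place: 3-methoxyphenyl in place of thiophen-2-yl on a double-bonded chain carbon bound to a double-bonded chain carbon.

Among the compounds with values here, only one measured step bears on this change. It exchanges another aromatic group at the same place, and it gave a 1.4-fold higher number from compound 1 to compound 2 (0.15 log units; within the scatter), within the scatter. On that basis, a third aromatic group at this place is expected to move the number little: the step of a 1.2-fold lower number from compound 2 to compound 3 (0.06 log units; within the scatter) is expected to stay within the scatter.

Compound 3 is therefore estimated at 8000 nM, with a range from 3000 nM to 20000 nM.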

Compound 3, half-maximal inhibitory concentration: 9760 nM
Compound 3: middle estimate off by 1.2-fold (0.09 log units), on the low side, within the range that was stated.
By their numbers in this assay, from the lowest: compounds 1, 2 and 3 (each within the scatter of the next).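

In this assay the change to 3-methoxyphenyl gives a 1.1-fold higher number from compound 2 to compound 3 (0.02 log units; within the scatter) and the wider comparison gives a 1.5-fold higher number from compound 1 to compound 3 (0.17 log units; within the scatter) so neither step can be read as a real difference. At this place on a double-bonded chain carbon, three aromatic end groups now stand within the scatter of one another, even though they differ in ring size and one of them carries a methoxy group. No measurement shown here explains why the numbers stay so close.

All three end groups are aromatic rings with no net charge, so this flat picture applies only to groups of that kind. On these data alone, what an amine, a carboxylic acid or a plain saturated carbon chain would do at this place remains open.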